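Hydroxy in Place of Hydrogen on a Quinoline Carboxamide

The source may hold more compounds than are shown below. What is called first, only, known or untested is meant among the compounds shown, and "the series" means these compounds.

Of the compounds shown here, two have been measured in an in vitro assay on UC11MG cells for binding affinity to Substance-P receptor (Homo sapiens), read by radioligand binding; on this read-out lower numbers stand for stronger inhibition and higher numbers for weaker inhibition. Compound 1 `Cc1nc2ccccc2c(-c2ccccc2)c1C(=O)N(C)Cc1cc(C(F)(F)F)cc(C(F)(F)F)c1` gives 3.1 nM, the lowest number of the two. Compound 2 `O=C(NCc1cc(C(F)(F)F)cc(C(F)(F)F)c1)c1c(CCl)nc2ccccc2c1-c1ccccc1` gives 26 nM, a higher number that lies beyond the usual scatter; compound 2 differs from compound 1 in more than one place, so no single change can be read from this pair. Compound 3 `CN(Cc1cc(C(F)(F)F)cc(C(F)(F)F)c1)C(=O)c1c(CO)nc2ccccc2c1-c1ccccc1` has not yet been measured. It differs from compound 1 in one place: hydroxy in place of hydrogen on a saturated chain carbon bound to an aromatic carbon. Among the measured compounds shown here, no measured pair shows this change on its own, so its size is open. The expectation is that the step from compound 1 to compound 3 is small, a 1.6-fold higher number from compound 1 to compound 3 (0.21 log units; within the scatter), toward a somewhat higher number, possibly not beyond the scatter. Compound 3 is therefore expected to give about 5 nM, within a range from 1.5 nM to 20 nM.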

Compound 3, half-maximal inhibitory concentration: 16 nM
Beside the measured number, compound 3's estimate is 3.2-fold (0.51 log units) below it, and the stated range covers the measured number.
By their numbers in this assay, from the lowest: compound 1; then compounds 3 and 2 (each within the scatter of the next).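

Read in this assay, the change from methyl to hydroxymethyl gives a 5.2-fold higher number from compound 1 to compound 3 (0.71 log units; beyond the scatter) and is the first single change at this position that can be read on its own. Hydroxy in place of hydrogen on this saturated chain carbon bound to an aromatic carbon therefore weakens inhibition by a modest step that lies beyond the usual scatter, something compound 2 could not show because it differs from compound 1 in more than one place. No measurement shown explains why this step occurs.

The compounds shown leave open whether other groups on this carbon, such as an amine, a methoxy group or a longer chain, would give a similar step. This single pair also leaves open whether the same change would have a similar effect on a different core.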